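Cyclopropyl for 3-fluorophenyl: compound 3 to compound 4

A few compounds are considered here, and "the series" means these few. Any claim that something is new, unique, unknown or untested is made for them only; others in the source may bear on it.

Going by the values given here, compound 3 `Cc1cc(NC(=O)Cn2nnc(-c3cccc(F)c3)n2)n(C2CCCCC2)n1` gives 81 nM in an assay on HEK293 cells for activation of Kir3.1/Kir3.2 (Homo sapiens), read by thallium flux (on this read-out higher numbers stand for an effect only at larger amounts of compound and lower numbers for an effect already at smaller amounts), the lowest of the three numbers measured so far. Compound 1 `Cc1cc(NC(=O)Cn2nnc(-c3ccccc3)n2)n(C2CCCC2)n1` gives 163 nM, within the scatter of compound 3, while compound 2 `Cc1cc(NC(=O)Cn2nnc(-c3ccccc3)n2)n(CC2CCCCC2)n1` gives 176 nM, beyond it. Among the compounds with values here, the only single-point step measured, a 1.1-fold higher number from compound 1 to compound 2 (0.03 log units; within the scatter), concerns the group on an aromatic nitrogen and leaves the read-out unchanged within the scatter.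

Compound 4 `Cc1cc(NC(=O)Cn2nnc(C3CC3)n2)n(C2CCCCC2)n1` differs from compound 3 by cyclopropyl in place of 3-fluorophenyl on an aromatic carbon. Within the data shown here, no measured step touches this position; the one step available, a 1.1-fold higher number from compound 1 to compound 2 (0.03 log units; within the scatter), lies at a different place and says nothing about the group carried on the five-membered aromatic ring with four nitrogens. Exchanging a six-membered aromatic ring for a three-membered non-aromatic ring is a larger alteration than any step seen, and with nothing to support keeping the low number of compound 3, a shift toward higher numbers is expected, beyond the scatter: a 6.2-fold higher number from compound 3 to compound 4 (0.79 log units; beyond the scatter). Compound 4 is therefore estimated at 500 nM in this assay, with the wide range 120 nM to 2500 nM reflecting the absence of any bearing precedent.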

Compound 4, half-maximal effective concentration: > 3000 nM
Compound 4: no number, only a limit (the forecaster's own chance of this, stated with the estimate: 10%); at least 6.0-fold (0.77 log units) between middle value and limit.
By their numbers in this assay, from the lowest: compounds 3, 1 and 2 (each within the scatter of the next, the first and the last beyond it). At a limit, above all of these: compound 4.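

At an aromatic carbon between two ring nitrogen atoms, cyclopropyl in place of 3-fluorophenyl gives an at least 37-fold higher number from compound 3 to compound 4 (1.56 log units; beyond the scatter) in this assay, the only step shown at this position, whereas the step on an aromatic nitrogen, a 1.1-fold higher number from compound 1 to compound 2 (0.03 log units; within the scatter), gave no sign that the read-out responds to a change of group. Compound 4 has no number here, only a limit of the assay: the limit of > 3000 nM in this assay, at which 1 of the 4 values shown sits. This position is thus sensitive to the group it carries, and for this pair a three-membered non-aromatic ring does not replace the six-membered aromatic ring without a large loss on this read-out.

Open, as far as these compounds go, is whether the fluorine of 3-fluorophenyl or the ring carrying it counts at this position. Also open, from the compounds shown here alone, is how a pyridyl ring, a longer alkyl chain or an amine would read on this carbon.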